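Swapping One Aromatic Group on a Shared Core

The source may report more compounds than this note shows. Statements on the series, on what has been measured and on what is new or still open speak of the compounds shown alone.

Two related compounds have been tested so far in a functional assay on A2780 cells (Homo sapiens) for antiproliferative activity, read by MTT assay, with a stated time of 48 h (a higher number here means a weaker inhibitor, a lower number a stronger inhibitor), and their results differ in kind. Compound 1 (`COc1ccc(-c2cncc3[nH]c(=O)n(Cc4cc(OC)c(OC)c(OC)c4)c23)cc1O`) reads > 20000 nM in this assay and this is a limit of the assay, not a number. For the measured compounds named here, compound 2 (`COc1ccc(-c2cc3c(cn2)[nH]c(=O)n3-c2cc(OC)c(OC)c(OC)c2)cn1`) gives 990 nM in this assay and this is the only true number available, which makes compound 2 the single firm reference point.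

The next molecule, compound 3 (`COc1ccc(-c2cc3c(cn2)[nH]c(=O)n3-c2cc(OC)c(OC)c(OC)c2)cc1N`), keeps the core of compound 2 and carries 3-amino-4-methoxyphenyl in place of 6-methoxypyridin-3-yl on an aromatic carbon. Going by the values given here, the two tested compounds differ in more than one place, so no measured step shows what this swap does, and any forecast must stay loose.

A moderate gain in strength is the expected direction, with an estimated 5.0-fold lower number from compound 2 to compound 3 (0.69 log units; beyond the scatter) in this assay as the likely size of the change. Compound 3 is estimated at 200 nM in this assay and is expected to fall between 20 nM and 2000 nM as a wide range.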

Compound 3, half-maximal inhibitory concentration: 640 nM
Compound 3: the middle estimate sits 3.2-fold (0.51 log units) below what was measured, within the range that was stated.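

For the compounds shown here, the first measured step at this position, on the aromatic carbon next to the ring nitrogen, is a 1.5-fold lower number from compound 2 to compound 3 (0.19 log units; within the scatter) in this assay, so 6-methoxypyridin-3-yl and 3-amino-4-methoxyphenyl cannot be told apart in this measurement. The earlier compounds shown here differed in more than one place and could not show this, but the pair now shows that a ring of carbon only, carrying an amino group and one more heavy atom, can replace the ring with a hetero atom without moving the reading beyond the usual scatter. The data shown give no cause for this result, and no measured property of either group bears on it.

A single swap says little about which part of the new group matters, so the roles of the amino group and the methoxy group remain unresolved. An acetamide or a carboxylic acid in place of the amino group, or an ethoxy group in place of the methoxy group, would test whether this position stays as insensitive to change as this one pair suggests.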